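The source may hold more compounds than are shown below. What is called first, only, known or untested is meant among the compounds shown, and "the series" means these compounds.

Working notes on the series, measured in an assay on isolated protein for inhibition of aldehyde dehydrogenase 1A1 (Homo sapiens), read by spectrophotometry, tested at 10 uM; on this read-out higher numbers stand for more inhibition at the one concentration tested (going by the name of the read-out) and lower numbers for less inhibition.

Compound 1 `CCn1c(CN2CCN(C(=O)C3CC3)CC2)nc2ccccc21` gives 20.8% in this assay, the lowest of the two numbers in hand. Among the compounds with values here, the only other measured member, compound 2 `Cc1ccc(C(=O)N2CCN(Cc3nc4ccccc4n3Cc3cccc(C)c3)CC2)cc1`, gives 64.9% in this assay, well beyond the scatter above compound 1. Within the data shown here, the two compounds differ in more than one place, so no single step connects them; the two values simply show that compound 1 sits at the low end of the series.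

The next compound is compound 3 `O=C(C1CC1)N1CCN(Cc2nc3ccccc3n2CC2CC2)CC1`, which differs from compound 1 in one place: cyclopropyl in place of methyl on a saturated chain carbon bound to an aromatic nitrogen. Among the measured compounds shown here, no measured pair covers this change, so its effect is unknown. Compound 3 is expected to give 30% in this assay, with a likely range from 10% to 55%. The expected step of a number 9.2 percentage points higher from compound 1 to compound 3 (within the scatter) is a small gain, roughly within the scatter, since compound 1 at 20.8% leaves room for modest movement only.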

Compound 3, a percentage reported as inhibition, at one concentration (the size of the read-out at that concentration, not a potency): 21.2%
Beside the measured number, compound 3's estimate is 8.8 percentage points above it; the range from low to high includes it.
By their numbers in this assay, from the lowest: compounds 1 and 3 (each within the scatter of the next); then compound 2.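

In this assay, within the data shown here, the first single-place reading at this position is a number 0.4 percentage points higher from compound 1 to compound 3 (within the scatter), for cyclopropyl in place of methyl on a saturated chain carbon bound to an aromatic nitrogen. Read one bond further out, as ethyl to cyclopropylmethyl, the exchange brings in a three-membered ring of carbon only, and the two compounds cannot be told apart on this read-out. Nothing at hand bears on why this exchange leaves the two compounds within the scatter of each other.

Open, on these data alone, is whether a longer chain such as n-butyl, or a chain ending in an amine or a carboxylic acid, would separate from compound 1 at this place. Also open, as far as these compounds go, is whether the same exchange would read the same way with the cyclopropyl carbonyl of compound 1 replaced by another acyl group.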